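Swapping 3,5-difluorophenyl for cyclohexyl

A few compounds are considered here, and "the series" means these few. Any claim that something is new, unique, unknown or untested is made for them only; others in the source may bear on it.

Compound 1 `Cc1cccc(NC(=O)c2nn(C)c(-c3ccc(F)cc3)c2C)n1`: 0.933 h
Compound 2 `Cc1cccc(NC(=O)c2nn(C)c(-c3ccc(F)cc3F)c2C)n1`: 1.27 h
Compound 3 `Cc1cccc(NC(=O)c2nn(C)c(-c3cc(F)cc(F)c3)c2C)n1`: 1.07 h

These three compounds share one core and differ only in the fluorines on the phenyl group. In an ADME assay on microsomes from liver (Rattus norvegicus) for metabolic stability (a lower number here means that the compound disappears faster, a higher number that the compound lasts longer), compound 3 gives 1.07 h, and it cannot be separated from the other two. The data show a 1.1-fold higher number from compound 1 to compound 3 (0.06 log units; within the scatter) and a 1.2-fold lower number from compound 2 to compound 3 (0.07 log units; within the scatter). The remaining pair shows a 1.4-fold higher number from compound 1 to compound 2 (0.13 log units; within the scatter). So changing the fluorine pattern has not moved the number beyond the scatter in any of these steps.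

Compound 4 `Cc1cccc(NC(=O)c2nn(C)c(C3CCCCC3)c2C)n1` makes a larger change, with cyclohexyl in place of 3,5-difluorophenyl (cyclohexyl in place of 3,5-difluorophenyl on an aromatic carbon). The group sits on an aromatic carbon of a five-membered aromatic ring with 2 nitrogen. Within the data shown here, an aromatic ring therefore gives way to a non-aromatic one, and none of the measured steps covers such a swap. Those small steps offer only a starting point, compound 3 at 1.07 h, and no direct guide to the size of this step. A lower number is nevertheless expected, as a judgement with wide uncertainty, and the estimated change is a 2.4-fold lower number from compound 3 to compound 4 (0.38 log units; beyond the scatter). In this assay compound 4 is expected at 0.45 h, with an estimated range from 0.15 h to 1.2 h.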

Compound 4, half-life: 0.133 h
Compound 4: middle estimate off by 3.4-fold (0.53 log units), on the high side, outside the stated range (below it).
By their numbers in this assay, from the lowest: compound 4; then compounds 1, 3 and 2 (each within the scatter of the next).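

In this assay, this position proves far more sensitive to the type of ring than to the fluorine pattern: cyclohexyl in place of 3,5-difluorophenyl gives an 8.0-fold lower number from compound 3 to compound 4 (0.91 log units; beyond the scatter), and the matching swaps give a 9.5-fold lower number from compound 2 to compound 4 (0.98 log units; beyond the scatter) and a 7.0-fold lower number from compound 1 to compound 4 (0.85 log units; beyond the scatter). All three steps point the same way and lie beyond the scatter, whichever fluorinated phenyl group leaves, whereas no step among the fluorinated compounds does, so among these four compounds the ring itself matters more than where its fluorines sit. Nothing available here shows what lies behind this drop.

Compound 4 removes the aromatic ring and the fluorines in a single change, so the compounds shown leave open which of the two accounts for the step; plain phenyl or 4,4-difluorocyclohexyl at the same place would help to separate them. Also open, as far as these compounds go, is how other groups would behave there, such as a smaller cyclopropyl ring, a pyridyl ring or a cyclohexyl ring carrying a hydroxyl group.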